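Amide cap exchange on the carboxamide core: compound 3 to compound 4

A few compounds are considered here, and "the series" means these few. Any claim that something is new, unique, unknown or untested is made for them only; others in the source may bear on it.

Compound 3 `CN1CCN(c2ccc(Nc3nc(-c4cccc(NC(=O)c5ccccc5F)c4)sc3C(N)=O)cc2)CC1` stands highest of the three numbers in a functional assay on Raji cells (Homo sapiens) for antiproliferative activity, read by CCK-8 assay, with a stated time of 72 h, tested at 40 uM (on this read-out lower numbers stand for less inhibition and higher numbers for more inhibition at the one concentration tested (going by the name of the read-out)), where compound 3 gives 97.3%. Compound 1 `CCOC(=O)c1sc(-c2cccc(NC(=O)c3ccc(C(F)(F)F)cn3)c2)nc1Nc1ccc(N2CCN(C)CC2)cc1` gives 20.8% and compound 2 `CN1CCN(c2ccc(Nc3nc(-c4cccc(NC(=O)c5ccc(C(C)(C)C)cc5)c4)sc3C(N)=O)cc2)CC1` gives 12.1%. Within the data shown here, the only single-site step measured so far is a number 85.2 percentage points higher from compound 2 to compound 3 (beyond the scatter), which shows that the group on the carbonyl carbon moves the read-out strongly. Compound 4 `CN1CCN(c2ccc(Nc3nc(-c4cccc(NC(=O)c5ccc(C(F)(F)F)cn5)c4)sc3C(N)=O)cc2)CC1` differs from compound 3 by 5-(trifluoromethyl)pyridin-2-yl in place of 2-fluorophenyl on a carbonyl carbon. Among the measured compounds shown here, no measured step covers this exchange directly; compound 1 carries the same entering group on a different core and sits far lower than compound 3, which argues for a drop, though the core difference leaves this uncertain. The expected step is a number 52.3 percentage points lower from compound 3 to compound 4 (beyond the scatter), and compound 4 is estimated at 45%, within 15% to 85%.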

Compound 4, a percentage reported as inhibition, at one concentration (the size of the read-out at that concentration, not a potency): 84.6%
For compound 4 the middle estimate is 39.6 percentage points below the measured one; measured number inside the range.
By their numbers in this assay, from the lowest: compounds 2 and 1 (each within the scatter of the next); then compound 4; then compound 3.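

In this assay, the group on the carbonyl carbon is not tied to 2-fluorophenyl: 5-(trifluoromethyl)pyridin-2-yl gives a number 12.7 percentage points lower from compound 3 to compound 4 (beyond the scatter) and stays far above the 4-(tert-butyl)phenyl cap, with a number 72.5 percentage points higher from compound 2 to compound 4 (beyond the scatter) for that exchange. With the 5-(trifluoromethyl)pyridin-2-yl cap held fixed, amino in place of ethoxy on the other carbonyl carbon gives a number 63.8 percentage points higher from compound 1 to compound 4 (beyond the scatter) in the same read-out, so the low number of compound 1 does not follow from that cap alone. No measurement available here explains these steps. Going by these compounds, whether a carboxylic acid or a methylamino group in place of amino would hold the number remains open. Potency also remains open, since the read-out comes from a single concentration.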